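Removing the Carbonyl from the Ether Side Chain

The source may report more compounds than this note shows. Statements on the series, on what has been measured and on what is new or still open speak of the compounds shown alone.

Compound 1 `COc1ccc2c(=O)c(-c3cc(OC)c(OC)cc3OC)coc2c1` is measured in a functional assay on HepG2 cells (Homo sapiens) for antiproliferative activity, read by MTT assay, with a stated time of 24 h (on this read-out lower numbers stand for stronger inhibition and higher numbers for weaker inhibition), and gives 2040 nM. Compound 2 `COc1cc(OC)c(-c2coc3cc(OCC(=O)c4cccc(C(F)(F)F)c4)ccc3c2=O)cc1OC` carries a longer ether side chain. In this assay compound 2 reaches only a limit, > 10000 nM, not a number. Compound 3 `COc1cc(OC)c(-c2coc3cc(OCc4ccc([N+](=O)[O-])cc4)ccc3c2=O)cc1OC` gives 2500 nM in this assay. The step of an at least 4.9-fold higher number from compound 1 to compound 2 (0.69 log units; beyond the scatter) lies beyond the scatter, the step of a 1.2-fold higher number from compound 1 to compound 3 (0.09 log units; within the scatter) lies within it, and the step of an at least 4.0-fold lower number from compound 2 to compound 3 (0.60 log units; beyond the scatter) lies beyond it again.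

Compound 4 `COc1cc(OC)c(-c2coc3cc(OCc4ccccc4C(F)(F)F)ccc3c2=O)cc1OC` has not yet been measured. Relative to compound 2 it differs in one place: 2-(trifluoromethyl)phenyl in place of (3-(trifluoromethyl)phenyl)carbonyl on a saturated chain carbon bound to an oxygen on an aromatic ring. Like the change from compound 2 to compound 3, this removes the carbonyl and keeps one six-membered aromatic ring on the chain carbon bound to the oxygen. Because compound 2 stands at the limit of > 10000 nM in this assay, at which 1 of the 3 values shown sits, while the carbonyl-free compound 3 gave a number, a lowering is expected for compound 4 in this assay, an at least 4.0-fold lower number from compound 2 to compound 4 (0.60 log units; beyond the scatter). Compound 4 is therefore estimated at 2500 nM, with a range from 1000 nM to 7000 nM.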

Compound 4, half-maximal inhibitory concentration: 6550 nM
Beside the measured number, compound 4's estimate is 2.6-fold (0.42 log units) below it; the measured number falls inside the stated range.
By their numbers in this assay, from the lowest: compounds 1 and 3 (each within the scatter of the next); then compound 4. At a limit, above all of these: compound 2.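

Compound 2 is held only at a limit in this assay, and an at least 1.5-fold lower number from compound 2 to compound 4 (0.18 log units; that floor lies within the scatter) gives a floor, not a true size. What is new is that removing the carbonyl does not settle the outcome, since the aromatic group left on the chain carbon also counts: a 2.6-fold higher number from compound 3 to compound 4 (0.42 log units; beyond the scatter). Compound 3 could not be told apart from compound 1, whereas 2-(trifluoromethyl)phenyl does separate from the hydrogen it replaces, a 3.2-fold higher number from compound 1 to compound 4 (0.51 log units; beyond the scatter).

Still open, on these data alone, is whether this gap follows from the substituent itself or from where it sits, as 2-(trifluoromethyl)phenyl and 4-nitrophenyl differ in both. Also open, as far as these compounds go, is how an amine or a carboxylic acid on that ring, or a longer chain between the oxygen and the ring, would read.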